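This account rests on a few compounds, and the source may have more. Where it says the series, first, only, none or still open, it means among the compounds named here.

Measured in a functional assay on HeLa cells (Homo sapiens) for antiproliferative activity, read by MTT assay, with a stated time of 48 h; a lower number here means a stronger inhibitor, a higher number a weaker inhibitor:
- compound 1 `COc1ccc(C(=O)c2ccc3c(c2)C=CC(C)(C)O3)c(NC(=O)CN)c1`: 580 nM
- compound 2 `CCNCC(=O)Nc1cc(OC)ccc1C(=O)c1ccc2c(c1)C=CC(C)(C)O2`: 3110 nM
- compound 3 `C=C(c1cc(OC)c(OC)c(OC)c1)c1ccc(OC)cc1NC(=O)CO`: 30 nM

Compound 3 has the lowest number of the three, and its gap to each of the other two lies beyond the scatter. Its core also differs from the core shared by compound 1 and compound 2.

Compound 4 `C=C(c1cc(OC)c(OC)c(OC)c1)c1ccc(OC)cc1NC(=O)CNCC` keeps the core of compound 3 but has ethylamino in place of hydroxy on a saturated chain carbon bound to a carbonyl carbon.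

Among the measured compounds shown here, no measured step makes this exact swap. The closest guide is a 5.4-fold higher number from compound 1 to compound 2 (0.73 log units; beyond the scatter), where ethyl replaces hydrogen on an amine nitrogen. That step is modest but beyond the scatter, and it runs toward a weaker inhibitor. Compound 2 also carries ethylamino, and its number is the highest of the three. The data do not show how far a step on one core carries over to another, so the expectation stays loose. A rise of similar size, toward a weaker inhibitor, seems most likely.

The expected change is a 5.0-fold higher number from compound 3 to compound 4 (0.70 log units; beyond the scatter). The estimated value for compound 4 is 150 nM, with an expected range from 40 nM to 600 nM.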

Compound 4, half-maximal inhibitory concentration: 430 nM
Beside the measured number, compound 4's estimate is 2.9-fold (0.46 log units) below it; measured number inside the range.
By their numbers in this assay, from the lowest: compound 3; then compounds 4 and 1 (each within the scatter of the next); then compound 2.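

In this assay, the core of compound 3 responds strongly to a change on the chain, with a 14-fold higher number from compound 3 to compound 4 (1.16 log units; beyond the scatter), a large step toward a weaker inhibitor. Until now, the measured compounds had only compared amines at this place, on a different core, whereas this pair sets hydroxy against ethylamino on a saturated chain carbon bound to a carbonyl carbon and shows that, on this core, the choice of group there matters a great deal. The two groups are counted alike for hydrogen-bond donors, hydrogen-bond acceptors and net charge, so those counts do not separate them, and nothing measured here explains the rise.

The change swaps the oxygen for a nitrogen and adds an ethyl group in one move, so the shown compounds cannot tell which part accounts for the step. A plain amino group on the core of compound 3 would divide the step into those two parts, while methoxy or a longer chain such as propylamino at the same place would show how much room the position leaves.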